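From a carboxylic acid to its hexyl ester

This account rests on a few compounds, and the source may have more. Where it says the series, first, only, none or still open, it means among the compounds named here.

Compound 1 `CCNS(=O)(=O)c1cccc(-c2ccc(OCC)cc2)c1`: 200000 nM
Compound 2 `CCOc1ccc(-c2cccc(C(=O)O)c2)cc1`: > 200000 nM
Compound 3 `CCCCCCOC(=O)c1cccc(-c2ccc(OCC)cc2)c1`: not yet measured

In an assay on COS-7 cells for inhibition of patatin-like phospholipase domain-containing protein 2 (Mus musculus) (on this read-out higher numbers stand for weaker inhibition and lower numbers for stronger inhibition), compound 1 gives 200000 nM. For compound 2 the result is only a limit, > 200000 nM. This is the limit of > 200000 nM in this assay, at which 1 of the 2 values shown sits. The step of a number no lower from compound 1 to compound 2 (the limit leaves the size open) therefore has no readable size. Compound 3 differs from compound 2 in that (hexyl in place of hydrogen on an oxygen next to a carbonyl group). Among the measured compounds shown here, no measured step touches this ester position; the single known step, a number no lower from compound 1 to compound 2 (the limit leaves the size open), changes another group and is itself bounded by a limit. Compound 3 is therefore expected to remain weak, with an estimated step of an at least 1.3-fold lower number from compound 2 to compound 3 (0.12 log units; that floor lies within the scatter). The estimated value of compound 3 is 150000 nM, expected between 30000 nM and 200000 nM.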

Compound 3, half-maximal inhibitory concentration: > 200000 nM
Compound 3 was reported as a limit; the forecaster's own chance of this, stated with the estimate: 50%; middle value at least 1.3-fold (0.12 log units) away from the limit.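

Compound 2 and compound 3 are both reported only as limits, so no step between them can be read: the limit of > 200000 nM in this assay, at which 2 of the 3 values shown sit.

The compounds shown leave open whether hexyl in place of hydrogen on an oxygen next to a carbonyl group changes inhibition at all.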